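The source may report more compounds than this note shows. Statements on the series, on what has been measured and on what is new or still open speak of the compounds shown alone.

In a functional assay on MCF7 cells (Homo sapiens) for antiproliferative activity (on this read-out lower numbers stand for stronger inhibition and higher numbers for weaker inhibition), compound 1 `CC(C)=CCc1cc(C(=O)Nc2cc3ccc(OCCC4CCCCN4)c(C)c3oc2=O)ccc1O`, with piperidin-2-yl on its side chain, gives 710 nM as its result. Compound 2 `CCCNCCCOc1ccc2cc(NC(=O)c3ccc(O)c(CC=C(C)C)c3)c(=O)oc2c1C`, with (propylamino)methyl in that place, gives 980 nM as its result, which makes a 1.4-fold higher number from compound 1 to compound 2 (0.14 log units; within the scatter) for this swap.

Compound 3 `CCCN(CCC)CCCOc1ccc2cc(NC(=O)c3ccc(O)c(CC=C(C)C)c3)c(=O)oc2c1C` gives > 50000 nM as its result, and this is a limit of the assay, not a number. It stands alone at the weak end of the series, at the limit of > 50000 nM in this assay, at which 1 of the 3 values shown sits, in the data so far.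

Compound 4 `CC(C)=CCc1cc(C(=O)Nc2cc3ccc(OCCCNC(C)C)c(C)c3oc2=O)ccc1O` differs from compound 3 by isopropylamino in place of dipropylamino on a saturated chain carbon, three bonds along the chain from an oxygen on an aromatic ring, which means isopropylamino in place of dipropylamino on a saturated chain carbon, three bonds along the chain from an oxygen on an aromatic ring.

The closest measured step runs the opposite way: propyl in place of hydrogen on an amine nitrogen gave an at least 51-fold higher number from compound 2 to compound 3 (1.70 log units; beyond the scatter) in that comparison. The other route to compound 3 was similar, with an at least 70-fold higher number from compound 1 to compound 3 (1.84 log units; beyond the scatter) as its size. Compound 4 has a hydrogen on its amine nitrogen again, like compound 2 with 980 nM as its result.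

A large step towards a lower number is therefore expected, estimated as an at least 50-fold lower number from compound 3 to compound 4 (1.69 log units; beyond the scatter) in this assay for this change. For compound 4 the estimated value is 1000 nM, with an expected range from 350 nM to 4000 nM in this read-out.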

Compound 4, half-maximal inhibitory concentration: 740 nM
Compound 4: middle estimate off by 1.4-fold (0.13 log units), on the high side; the range from low to high includes it.
By their numbers in this assay, from the lowest: compounds 1, 4 and 2 (each within the scatter of the next). At a limit, above all of these: compound 3.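

In this assay, isopropylamino in place of dipropylamino restores activity, a change seen as an at least 67-fold lower number from compound 3 to compound 4 (1.82 log units; beyond the scatter). The branched isopropyl and the straight propyl on the amine nitrogen cannot be told apart, with a 1.3-fold lower number from compound 2 to compound 4 (0.12 log units; within the scatter), and the same holds for (isopropylamino)methyl against piperidin-2-yl, with a 1.0-fold higher number from compound 1 to compound 4 (0.02 log units; within the scatter), so the three compounds that keep a hydrogen on this nitrogen, compound 1, compound 2 and compound 4, sit together. Compound 3, the only one with no hydrogen there, gives a limit of the assay and not a number: the limit of > 50000 nM in this assay, at which 1 of the 4 values shown sits.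

As far as these compounds go, whether the loss in compound 3 follows from the missing hydrogen or from the larger dipropylamino group stays open, and a dimethylamino group in the same place would separate the two. From the compounds shown here alone, how a longer chain between the oxygen and the amine would read also remains open.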